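A few compounds are considered here, and "the series" means these few. Any claim that something is new, unique, unknown or untested is made for them only; others in the source may bear on it.

Measured so far in a functional assay on the whole organism (stomach) for inhibition, with Rattus norvegicus as the target, at a dose of 100 mg/kg by the intraduodenal route; a lower number here means less inhibition, a higher number more inhibition at the dose given (going by the name of the read-out):
compound 1, `N=C(S)CCCn1nc(-c2ccccc2)ccc1=O`, gives 75.6%;
compound 2, `N#CCCn1nc(-c2ccccc2)ccc1=O`, gives 10.1%;
compound 3, `CC/N=C(\S)CCn1nc(-c2ccccc2)ccc1=O`, gives 50.3%.

Compound 3 stands second highest of the three. Its nearest neighbour is compound 1, with a number 25.3 percentage points lower from compound 1 to compound 3 (beyond the scatter); compound 2 lies furthest away, with a number 40.2 percentage points higher from compound 2 to compound 3 (beyond the scatter). The remaining step, a number 65.5 percentage points lower from compound 1 to compound 2 (beyond the scatter), shows that the group on the saturated chain carbon two bonds along the chain from the aromatic nitrogen carries most of the read-out in this small set.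

Compound 4, `CNC(=O)CCn1nc(-c2ccccc2)ccc1=O`, is not yet measured. It differs from compound 3 in one place: a group of 4 heavy atoms (2 carbon, 1 nitrogen, 1 oxygen; no ring) in place of a group of 5 heavy atoms (3 carbon, 1 nitrogen, 1 sulfur; no ring), on a saturated chain carbon, two bonds along the chain from an aromatic nitrogen. Among the compounds with values here, no measured step exchanges a thioamide for an amide, so none bears directly on this change. What the series does show is a sharp drop in the read-out in a number 65.5 percentage points lower from compound 1 to compound 2 (beyond the scatter). A more modest drop appears in a number 25.3 percentage points lower from compound 1 to compound 3 (beyond the scatter). A change at that place of the size seen in compound 4 is therefore expected to move the number beyond the scatter, most likely downward, with a number 22.3 percentage points lower from compound 3 to compound 4 (beyond the scatter). For compound 4 the expected value is 28%, estimated to lie between 8% and 55%.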

Compound 4, a percentage reported as inhibition, in the whole organism at one dose (the size of the read-out at that dose, not a potency): 3.5%
The estimate for compound 4 lay 24.5 percentage points above the measured number; measured number outside the range, below it.
By their numbers in this assay, from the lowest: compounds 4 and 2 (each within the scatter of the next); then compound 3; then compound 1.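

In this assay, methylcarbamoyl on a saturated chain carbon, two bonds along the chain from an aromatic nitrogen, costs most of the read-out against the sulfur-bearing group of compound 3, with a number 46.8 percentage points lower from compound 3 to compound 4 (beyond the scatter), and against that of compound 1, with a number 72.1 percentage points lower from compound 1 to compound 4 (beyond the scatter). Set against the nitrile, methylcarbamoyl does not separate, with a number 6.6 percentage points lower from compound 2 to compound 4 (within the scatter), so the two groups without sulfur stand together under the two groups with sulfur, a split that holds for all four compounds with none against it. Nothing available gives a reason for this split.

On these data alone, the step to compound 4 exchanges sulfur for oxygen and also goes from a group of 3 carbon to a group of 2 carbon, so the share of each part stays open, and ethylcarbamoyl at this place would separate the two. Also open, as far as these compounds go, is whether sulfur itself is what matters, which a carboxylic acid or a primary amine at this place, or a longer chain carrying methylcarbamoyl, could begin to test in this assay.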